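The source may hold more compounds than are shown below. What is called first, only, known or untested is meant among the compounds shown, and "the series" means these compounds.

Measured compounds in a functional assay on JeKo-1 cells (Homo sapiens) for inhibition, read by luminescence and CellTiter-Glo, with a stated time of 72 h; a higher number here means a weaker inhibitor, a lower number a stronger inhibitor:
- compound 1 `O=C(CCl)N1CCCC(n2nc(-c3ccc(Oc4ccccc4)cc3)cc2CO)C1` gives 7800 nM
- compound 2 `C=CC(=O)Nc1ccc(Cn2nc(-c3ccc(Oc4ccccc4)cc3)cc2CO)cc1` gives 8000 nM
- compound 3 `C=CC(=O)N1CCCC(n2nc(-c3ccc(Oc4ccccc4)cc3)cc2CO)C1` gives 11900 nM

Compound 3 carries the highest of the three numbers, but its distance to compound 2 and to compound 1 is within the scatter, so the three compounds cannot be ordered on these data. For the measured compounds named here, the only single-point step among them, a 1.5-fold higher number from compound 1 to compound 3 (0.18 log units; within the scatter), concerns the acyl group on the piperidine and stays within the scatter.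

Compound 4 `C=CC(=O)N1CCCC(n2nc(-c3ccc(Oc4ccccc4)cc3)cc2C(=O)O)C1` differs from compound 3 in the group on the five-membered aromatic ring: carboxy in place of hydroxymethyl on an aromatic carbon. Going by the values given here, no measured pair covers this exchange; the step from compound 1 to compound 3 touches a different part of the molecule and offers no guide for the direction or size of this one. With nothing in the data pointing either way, the expectation in this assay is a step of a 1.0-fold higher number from compound 3 to compound 4 (0.00 log units; within the scatter), that is, no change beyond the scatter, with a wide range on both sides. Compound 4 is therefore estimated at 12000 nM, with a range from 4000 nM to 40000 nM.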

Compound 4, half-maximal inhibitory concentration: > 60000 nM
Compound 4: a limit, no number (the forecaster's own chance of this, stated with the estimate: 20%); middle value at least 5.0-fold (0.69 log units) away from the limit.
By their numbers in this assay, from the lowest: compounds 1, 2 and 3 (each within the scatter of the next). At a limit, above all of these: compound 4.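

Carboxy in place of hydroxymethyl on this aromatic carbon gives an at least 5.0-fold higher number from compound 3 to compound 4 (0.70 log units; beyond the scatter) and is the only step in the series so far that lies beyond the scatter, whereas the exchange of the acyl group on the piperidine stayed within it. In this assay compound 4 gives > 60000 nM as a limit of the assay, not a number. The size of the step is thus bounded on one side only: the limit of > 60000 nM in this assay, at which 1 of the 4 values shown sits.

As far as these compounds go, whether the weaker inhibition is specific to carboxy or extends to other groups at this position, such as an amine, a methyl ester or a primary amide, remains open. Also open, from the compounds shown here alone, is whether the same exchange has a similar effect on the cores of compound 1 and compound 2.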